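The source may hold more compounds than are shown below. What is called first, only, known or untested is meant among the compounds shown, and "the series" means these compounds.

Working notes on the series. In a functional assay on DU-145 cells (Homo sapiens) for cytotoxicity, read by CCK-8 assay (a higher number here means a weaker inhibitor, a lower number a stronger inhibitor), compound 1 `Oc1ccc(-c2cc(-c3ccsc3)cc(-c3cccc(O)c3)n2)cc1` gives 2230 nM. Within the data shown here, compound 2 `Oc1ccc(-c2cc(-c3ccsc3)cc(-c3ccc(O)cc3)n2)cc1` carries 4-hydroxyphenyl in place of 3-hydroxyphenyl on an aromatic carbon and in this assay gives 2060 nM; the step of a 1.1-fold lower number from compound 1 to compound 2 (0.03 log units; within the scatter) is the only direct measurement of this change so far. Compound 3 `Oc1cccc(-c2cc(-c3ccoc3)cc(-c3ccccc3O)n2)c1` gives 2790 nM in this assay. The core of compound 3 differs from the core of compound 1 in more than one place, and the difference between the two cores is not broken down here; the two values lie within the scatter of each other, as do those of compound 3 and compound 2.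

Compound 4 `Oc1ccc(-c2cc(-c3ccoc3)cc(-c3ccccc3O)n2)cc1` has not been measured. It carries 4-hydroxyphenyl in place of 3-hydroxyphenyl on an aromatic carbon. Among the measured compounds shown here, this is the same kind of change as the one from compound 1 to compound 2, but not the same: in compound 1 the place is meta to a 4-hydroxyphenyl group and meta to a thiophen-3-yl group, whereas in compound 3 it is meta to a 2-hydroxyphenyl group and meta to a furan-3-yl group.

The step from compound 3 to compound 4 is expected to be a 1.1-fold lower number from compound 3 to compound 4 (0.05 log units; within the scatter), set beside the earlier 1.1-fold lower number from compound 1 to compound 2 (0.03 log units; within the scatter), which stayed within the scatter. For the measured compounds named here, the expectation rests on compound 1 and compound 2 alone, since only one example of this change exists. Compound 4 is therefore estimated to give 2500 nM in this assay, within a range from 1300 nM to 5000 nM.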

Compound 4, half-maximal inhibitory concentration: 28000 nM
Beside the measured number, compound 4's estimate is 11-fold (1.05 log units) below it, and the stated range ends below it.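

In this assay, the change from 3-hydroxyphenyl to 4-hydroxyphenyl on the core of compound 3 gives a 10-fold higher number from compound 3 to compound 4 (1.00 log units; beyond the scatter), so the change does not carry over with the same size from the core of compound 1 to the core of compound 3: the same change on two cores in this assay, a 1.1-fold lower number (0.03 log units; within the scatter) from compound 1 to compound 2 and a 10-fold higher number (1.00 log units; beyond the scatter) from compound 3 to compound 4, 11-fold (1.04 log units) apart, beyond the scatter of two such steps

The two cores differ in more than one place, and these pairs do not tell whether the furan-3-yl group in place of thiophen-3-yl, the 2-hydroxyphenyl group in place of 4-hydroxyphenyl, or the two together set the size of the step. With a single pair on each core, the result shows a dependence on the core for these four compounds only; it gives no general rule for the series and no cause for the gap.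

Open, on these data alone, is how the same change behaves on a core that differs from the core of compound 3 in one place only, with thiophen-3-yl in place of furan-3-yl or with the 2-hydroxyphenyl group moved to another hydroxyphenyl form. Also open, as far as these compounds go, is whether an amine or a carboxylic acid in place of the hydroxyl on the changing ring would follow the same dependence on the core.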